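A few compounds are considered here, and "the series" means these few. Any claim that something is new, unique, unknown or untested is made for them only; others in the source may bear on it.

Compound 1 `COC(=O)Nc1cccc(-c2ccc(N(C)C)cc2)c1` gives 5000 nM in an assay on COS-7 cells for inhibition of patatin-like phospholipase domain-containing protein 2 (Mus musculus); on this read-out lower numbers stand for stronger inhibition and higher numbers for weaker inhibition. Compound 2 `CN(C)c1ccc(-c2cccc(NC(=O)C(C)(C)C)c2)cc1` is reported in this assay only as a limit of the assay, > 200000 nM, so its position rests on a limit rather than a number. The step of an at least 40-fold higher number from compound 1 to compound 2 (1.60 log units; beyond the scatter) was large. Compound 3 `CN(C)C(=O)N(C)c1cccc(-c2ccc(N(C)C)cc2)c1` has not yet been measured; it differs from compound 2 by (dimethylcarbamoyl)(methyl)amino in place of ((tert-butyl)carbonyl)amino on an aromatic carbon. Going by the values given here, only the step of an at least 40-fold higher number from compound 1 to compound 2 (1.60 log units; beyond the scatter) bears on this change, and since the tert-butyl group that came with it leaves again, compound 3 is expected to sit between the two measured numbers, at an estimated 50000 nM with a range from 8000 nM to 200000 nM. The expected step is an at least 4.0-fold lower number from compound 2 to compound 3 (0.60 log units; beyond the scatter).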

Compound 3, half-maximal inhibitory concentration: 70000 nM
For compound 3 the middle estimate is 1.4-fold (0.15 log units) below the measured one; the range from low to high includes it.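

With (dimethylcarbamoyl)(methyl)amino on this aromatic carbon, compound 3 gives a measured number where ((tert-butyl)carbonyl)amino gave none, a change that amounts to an at least 2.8-fold lower number from compound 2 to compound 3 (0.45 log units; beyond the scatter). Compound 2 stands only at a limit of the assay, so this step is a bound and not a size: the limit of > 200000 nM in this assay, at which 1 of the 3 values shown sits. Even so, the new group does not recover the level set by (methoxycarbonyl)amino, with a 14-fold higher number from compound 1 to compound 3 (1.15 log units; beyond the scatter).

Whether the methyl on the nitrogen or the dimethylamino end accounts for that gap stays open, as the two change together. Going by these compounds, how an ethoxy group on the carbonyl would read at this position also remains open.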